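Replacing a saturated ring with a butanamide side chain

A few compounds are considered here, and "the series" means these few. Any claim that something is new, unique, unknown or untested is made for them only; others in the source may bear on it.

Compound 1 `Cc1cc(C)c(S(=O)(=O)N2CCC(N3CCC(O)CC3)CC2)c(C)c1`: in an ADME assay on HCT-116 cells (Homo sapiens) for cytotoxicity, read by CellTiter-Glo, with a stated time of 72 h (a higher number here means a weaker inhibitor, a lower number a stronger inhibitor), compound 1 gives > 5000 nM, which is a limit of the assay rather than a number.
Compound 2 `Cc1cc(C)c(S(=O)(=O)N2CCC(N3CCC(C(C)C)CC3)CC2)c(C)c1`: in this assay compound 2 gives > 5000 nM, again a limit.
Compound 3 `Cc1cc(C)c(S(=O)(=O)N2CCC(N3CCC(C)OC3)CC2)c(C)c1`: in this assay compound 3 gives > 5000 nM, also a limit.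

Compound 3 therefore stands at the same limit as the other two measured compounds, and no ranking among them can be read from the numbers. The three steps between them, a step that the two limits leave unreadable from compound 1 to compound 2, a step that the two limits leave unreadable from compound 1 to compound 3 and a step that the two limits leave unreadable from compound 2 to compound 3, are all unreadable, as the limit of > 5000 nM in this assay, at which 3 of the 3 values shown sit, shows.

Compound 4 `CCCC(=O)NC1CCN(S(=O)(=O)c2c(C)cc(C)cc2C)CC1` differs from compound 3 as follows: a group of 6 heavy atoms (4 carbon, 1 nitrogen, 1 oxygen; no ring) in place of a group of 7 heavy atoms (5 carbon, 1 nitrogen, 1 oxygen; one six-membered non-aromatic ring with 2 hetero atoms), on a saturated ring carbon. Among the measured compounds shown here, none of the measured steps bears on this change, and none of them gives a readable size in this assay. Nothing in the data suggests that compound 4 should reach a measurable value, so the step that the limit leaves unreadable from compound 3 to compound 4 is expected to be none beyond the scatter. For compound 4 in this assay the expected value is 8000 nM, with a likely range from 3000 nM to 30000 nM.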

Compound 4, half-maximal inhibitory concentration: > 5000 nM
Compound 4: only a limit was reported; the forecaster's own chance of this, stated with the estimate: 85%; the middle value does not contradict the limit.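

The steps from compound 1, compound 2 and compound 3 to compound 4 cannot be read, since all four results are a limit of the assay rather than a number: the limit of > 5000 nM in this assay, at which 4 of the 4 values shown sit.

Going by these compounds, whether any group at this saturated ring carbon gives a measurable value in this assay stays open.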